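From compound 3 to compound 4: a larger group enters

This account rests on a few compounds, and the source may have more. Where it says the series, first, only, none or still open, it means among the compounds named here.

In a physicochemical assay for lipophilicity, measured as octanol-water partition (a higher number here means a more lipophilic compound, a lower number a more polar compound), compound 1 `COc1ccc(/C=N/c2ccccc2C(=O)NNc2ccnc3cc(Cl)ccc23)cc1OC` gives 4.97, compound 2 `O=C(NNc1ccnc2cc(Cl)ccc12)c1ccccc1/N=C/c1ccc(O)cc1` gives 4.65 and compound 3 `O=C(NNc1ccnc2cc(Cl)ccc12)c1ccccc1/N=C/c1cccs1` gives 4.78. Compound 3 thus lies within the scatter of both other compounds. Compound 4 `O=C(NNc1ccnc2cc(Cl)ccc12)c1ccccc1/N=C/c1cc2ccccc2[nH]c1=O` carries a group of 11 heavy atoms (9 carbon, 1 nitrogen, 1 oxygen; one six-membered aromatic ring of carbon only, one six-membered aromatic ring with 1 hetero atom) in place of a group of 5 heavy atoms (4 carbon, 1 sulfur; one five-membered aromatic ring with 1 hetero atom), on a carbon with a double bond to nitrogen. All three measured steps change this same place: a number 0.32 log units lower from compound 1 to compound 2 (beyond the scatter), a number 0.19 log units lower from compound 1 to compound 3 (within the scatter) and a number 0.13 log units higher from compound 2 to compound 3 (within the scatter). Only the first of these passes the scatter, and it is modest. For the measured compounds named here, none of the measured compounds carries the entering group, so these steps are only a loose guide. In this assay, no step beyond the scatter is therefore expected, and no direction can be favoured. The expected step is a number 0.03 log units lower from compound 3 to compound 4 (within the scatter). Compound 4 is estimated at 4.75, with an expected range of 4.25 to 5.25.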

Compound 4, partition coefficient: 4.65
Compound 4: middle estimate off by 0.10 log units, on the high side; low and high end bracket the measured number.
By their numbers in this assay, from the lowest: compounds 2, 4, 3 and 1 (each within the scatter of the next, the first and the last beyond it).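

In this assay, a group of 11 heavy atoms on the carbon with a double bond to nitrogen gives no step beyond the scatter from the two smaller groups (a number 0.13 log units lower from compound 3 to compound 4 (within the scatter); no change at the digits printed from compound 2 to compound 4 (within the scatter)). Only the 3,4-dimethoxyphenyl group stands apart (a number 0.32 log units lower from compound 1 to compound 4 (beyond the scatter)), so compound 4 and compound 2 both lie beyond the scatter of compound 1. Nothing available explains these numbers. Going by these compounds, whether an amine or a carboxylic acid at this place would move the number beyond the scatter of compound 3 remains open.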